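Methyl to Ethyl on the Aryl Group of Compound 3

The source may report more compounds than this note shows. Statements on the series, on what has been measured and on what is new or still open speak of the compounds shown alone.

Three measured compounds share one core. In an assay on Prostate gland (Oryctolagus cuniculus) for inhibition of Adrenergic receptor alpha-1 (Homo sapiens) (a higher number here means weaker binding, a lower number tighter binding), compound 1 `COc1ccccc1N1CCN(CCCOc2ccc(C(=O)Nc3ccccc3OCCCC(=O)O)cc2)CC1` gives 100 nM. Compound 2 `COc1ccccc1N1CCN(CCC(Oc2ccc(NC(=O)c3ccccc3OCCCC(=O)O)cc2)c2ccccc2)CC1` gives 79.4 nM in this assay, and compound 3 `COc1ccccc1N1CCN(CCC(Oc2ccc(NC(=O)c3ccccc3OCCCC(=O)O)cc2)c2ccc(C)cc2)CC1` gives 79.4 nM. Compound 3 thus stands level with compound 2 and, together with it, at the lowest number of the three, while compound 1 lies only slightly apart, within the scatter. Compound 4 `CCc1ccc(C(CCN2CCN(c3ccccc3OC)CC2)Oc2ccc(NC(=O)c3ccccc3OCCCC(=O)O)cc2)cc1` carries the change (methyl in place of hydrogen on a saturated chain carbon bound to an aromatic carbon); read one bond further out it is methyl to ethyl, or 4-methylphenyl to 4-ethylphenyl. Among the compounds with values here, the only step that bears on it is no change at the digits printed from compound 2 to compound 3 (within the scatter), which showed no change. No step beyond the scatter is therefore expected, a 1.0-fold lower number from compound 3 to compound 4 (0.00 log units; within the scatter). Compound 4 is estimated at 79 nM, within 40 nM to 160 nM.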

Compound 4, dissociation constant: 200 nM
Estimate against measurement, compound 4: 2.5-fold (0.40 log units) below, and the stated range ends below it.
By their numbers in this assay, from the lowest: compounds 2, 3, 1 and 4 (each within the scatter of the next, the first and the last beyond it).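

In this assay, within the data shown here, the change from 4-methylphenyl to 4-ethylphenyl is the first on this aryl group to go beyond the scatter, giving a 2.5-fold higher number from compound 3 to compound 4 (0.40 log units; beyond the scatter) where the earlier methyl step gave no change at the digits printed from compound 2 to compound 3 (within the scatter) and nothing more. Ethyl in place of hydrogen on the aromatic carbon likewise gives a 2.5-fold higher number from compound 2 to compound 4 (0.40 log units; beyond the scatter) and so, among these compounds, this position takes methyl without a shift but binds modestly weaker with ethyl. Nothing available accounts for the difference. From the compounds shown here alone, whether a longer chain such as propyl, or a methoxy group or chlorine, would weaken binding further at this position stays open.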